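Removing the Methoxy Group: What Compound 4 Might Show

This account rests on a few compounds, and the source may have more. Where it says the series, first, only, none or still open, it means among the compounds named here.

Compound 1, `CN(C)c1ccc(C(=O)N(CCC(=O)NCc2ccc(Cl)cc2)Cc2ccc(C(=O)NO)cc2)cc1`, gives 310 nM in a functional assay on IMR-32 cells (Homo sapiens) for antiproliferative activity, with a stated time of 72 h; on this read-out lower numbers stand for stronger inhibition and higher numbers for weaker inhibition.
Compound 2, `COc1ccc(C(=O)N(CCC(=O)NCc2ccccc2)Cc2ccc(C(=O)NO)cc2)cc1`, gives 1090 nM in this assay.
Compound 3, `Cc1ccc(NC(=O)CCN(Cc2ccc(C(=O)NO)cc2)C(=O)c2ccc(N(C)C)cc2)cc1`, gives 300 nM in this assay.

The three compounds share one core and differ in two regions: the group on the amide-type nitrogen and the substituted benzoyl part. Compound 2 stands highest of the three numbers; compound 1 and compound 3 both give lower numbers, and both gaps lie beyond the scatter. Going by the values given here, the only single-point step measured, a 1.0-fold lower number from compound 1 to compound 3 (0.01 log units; within the scatter), changes the amide-type nitrogen side and leaves the benzoyl part untouched.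

Compound 4, `O=C(CCN(Cc1ccc(C(=O)NO)cc1)C(=O)c1ccccc1)NCc1ccccc1`, differs from compound 2 in the benzoyl part: hydrogen in place of methoxy on an aromatic carbon. Among the compounds with values here, no measured step changes that position alone, and compound 2 differs from compound 1 and compound 3 in two places at once, so their gap cannot be assigned to the methoxy. Within the data shown here, with no step bearing on it, the expectation is a 1.1-fold lower number from compound 2 to compound 4 (0.04 log units; within the scatter), a step not beyond the scatter. Compound 4 is therefore estimated at 1000 nM, with a range from 400 nM to 2500 nM.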

Compound 4, half-maximal inhibitory concentration: 2360 nM
Estimate against measurement, compound 4: 2.4-fold (0.37 log units) below; the measured number falls inside the stated range.
By their numbers in this assay, from the lowest: compounds 3 and 1 (each within the scatter of the next); then compound 2; then compound 4.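

Going by these compounds alone, the position para to a large group on this aromatic ring is not a silent one: in this assay, the step of a 2.2-fold higher number from compound 2 to compound 4 (0.34 log units; beyond the scatter) is the first measured change made at this place alone, and it lies beyond the scatter. Within this pair, then, the methoxy group goes with the lower number and the plain benzoyl group with the higher one, although the step is modest and rests on a single pair carrying the benzylamide side of compound 2. Nothing measured here speaks to why the number moves with this change.

Going by these compounds, it remains open whether a hydroxyl group or a fluorine on this same carbon would fall nearer compound 2 or compound 4. The compounds shown also cannot say how the dimethylamino group of compound 1 and compound 3 compares with methoxy, since those compounds differ from compound 2 in two places.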